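A few compounds are considered here, and "the series" means these few. Any claim that something is new, unique, unknown or untested is made for them only; others in the source may bear on it.

Working notes on the series

The shared core is kept throughout. Compound 1 is `O=C(N/N=C1\C(=O)Nc2ccccc21)Nc1ccccc1`, compound 2 is `Cc1ccc2c(c1)/C(=N/NC(=S)Nc1ccccc1)C(=O)N2` and compound 3 is `O=C1Nc2ccccc2/C1=N/NC(=S)Nc1ccc(Cl)cc1`. All three have been tested in an ADME assay on RD cells (Homo sapiens) for cytotoxicity; a lower number here means that less compound is tolerated, a higher number that more compound is tolerated. Compound 1 reaches only the limit of the assay, > 25000 nM. Compound 2 likewise gives only the limit, > 25000 nM. Compound 3 also stops at the limit, > 25000 nM. No number is known for compound 3, only this limit, and it stands where the two other values of the series stand, since (the limit of > 25000 nM in this assay, at which 3 of the 3 values shown sit). Among the measured compounds shown here, nothing so far separates one compound from another in this assay.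

Compound 4 is `O=C1Nc2ccccc2/C1=N/NC(=S)Nc1cccc(Cl)c1` and has not yet been tested in this assay. It differs from compound 3 by 3-chlorophenyl in place of 4-chlorophenyl on an amide-type nitrogen. For the measured compounds named here, no measured step in this assay is at hand to set the size of such a change, and the three values shown give no direction. The expectation for the step that the limit leaves unreadable from compound 3 to compound 4 is therefore none beyond the scatter of repeated measurements in this assay. Compound 4 is thus expected to give about 30000 nM in this assay, most likely again only the limit, in a range from 15000 nM to 80000 nM.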

Compound 4, half-maximal cytotoxic concentration: > 25000 nM
Compound 4: a limit, no number; the forecaster's own chance of this, stated with the estimate: 85%; the middle value lies beyond the limit too.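

In this assay compound 4 gives > 25000 nM, which is a limit and not a number. Compound 3 also stands at a limit, so no step can be read between compound 3 and compound 4: the limit of > 25000 nM in this assay, at which 4 of the 4 values shown sit.

The compounds shown leave open where the half-maximal cytotoxic concentration of any of them lies, and whether 3-chlorophenyl and 4-chlorophenyl differ at all in this assay.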